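Swapping the thiazole for an ethylpyrrolidine: what solubility follows

A few compounds are considered here, and "the series" means these few. Any claim that something is new, unique, unknown or untested is made for them only; others in the source may bear on it.

Compound 2 `Cc1cc(NCc2nccs2)n2nc(C)c(-c3ccccc3)c2n1` is one of two compounds sharing a core, the other being compound 1 `Cc1cc(NCc2ncc[nH]2)n2nc(C)c(-c3ccccc3)c2n1`. In a physicochemical assay for solubility, read by HPLC, using the shake flask method, measured as kinetic solubility, with a stated time of 2 h, at pH 7.4 (on this read-out higher numbers stand for higher solubility and lower numbers for lower solubility), compound 2 gives 108000 nM. Compound 1 reaches only the limit of the assay, < 5000 nM, so only compound 2 has a definite number. Within the data shown here, the one measured step, an at least 21-fold higher number from compound 1 to compound 2 (1.33 log units; beyond the scatter), shows a large rise, with compound 1 sitting at the limit of < 5000 nM in this assay, at which 1 of the 2 values shown sits. Compound 3 `CCN1CCCC1CNc1cc(C)nc2c(-c3ccccc3)c(C)nn12` differs from compound 2 by 1-ethylpyrrolidin-2-yl in place of 1,3-thiazol-2-yl on a saturated chain carbon bound to a nitrogen on an aromatic ring. Among the measured compounds shown here, that change is of a different kind from the measured step, which swapped one aromatic heterocycle for another, so no measured step directly bears on it. An increase is nevertheless expected, as a 3.2-fold higher number from compound 2 to compound 3 (0.51 log units; beyond the scatter), though with wide uncertainty in both directions. Compound 3 is therefore estimated at 350000 nM in this assay, within 80000 nM to 1500000 nM.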

Compound 3, solubility: 172000 nM
Estimate against measurement, compound 3: 2.0-fold (0.31 log units) above, and the stated range covers the measured number.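

At this place, on a saturated chain carbon bound to a nitrogen on an aromatic ring, the earlier step compared only aromatic rings, and now a non-aromatic ring has been read as well. In this assay, 1-ethylpyrrolidin-2-yl in place of 1,3-thiazol-2-yl gives a 1.6-fold higher number from compound 2 to compound 3 (0.20 log units; within the scatter), so the two groups cannot be told apart here, while in place of 1H-imidazol-2-yl it gives an at least 34-fold higher number from compound 1 to compound 3 (1.53 log units; beyond the scatter), which shows that the large gap to compound 1 is not tied to the thiazole. The value of compound 1 is a limit and not a number, so the true size of that gap stays unknown: the limit of < 5000 nM in this assay, at which 1 of the 3 values shown sits.

The compounds shown do not tell why compound 1 stands apart. On these data alone, what a morpholine or a carboxylic acid would give at this place also remains open.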